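Estimating Compound 4 from Two Single Structural Changes

The source may hold more compounds than are shown below. What is called first, only, known or untested is meant among the compounds shown, and "the series" means these compounds.

Compound 1 `COc1cc2c(Oc3ccc(NC(=O)c4nn(-c5ccccc5F)c(=O)c5ccccc45)cc3F)ccnc2cc1OCCCN1CCCC1` gives 950 nM in a functional assay on MDA-MB-231 cells (Homo sapiens) for cytotoxicity, read by MTT assay, with a stated time of 72 h; on this read-out higher numbers stand for weaker inhibition and lower numbers for stronger inhibition.
Compound 2 `COc1cc2c(Oc3ccc(NC(=O)c4nn(-c5ccc(Br)cc5)c(=O)c5ccccc45)cc3F)ccnc2cc1OCCCN1CCCC1` gives 1160 nM in this assay.
Compound 3 `COc1cc2c(Oc3ccc(NC(=O)c4nn(-c5ccccc5F)c(=O)c5ccccc45)cc3F)ccnc2cc1OCCCN1CCC(C)CC1` gives 670 nM in this assay.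

Three measured compounds share one core and differ in only two places. From compound 1 to compound 2 the change is 4-bromophenyl in place of 2-fluorophenyl on an aromatic nitrogen and the step is a 1.2-fold higher number from compound 1 to compound 2 (0.09 log units; within the scatter). From compound 1 to compound 3 the change is 4-methylpiperidin-1-yl in place of pyrrolidin-1-yl on a saturated chain carbon, three bonds along the chain from an oxygen on an aromatic ring and the step is a 1.4-fold lower number from compound 1 to compound 3 (0.15 log units; within the scatter). Both steps are within the usual scatter of repeated measurements, so none of the three compounds can be called stronger or weaker than another on this evidence.

Compound 4 `COc1cc2c(Oc3ccc(NC(=O)c4nn(-c5ccc(Br)cc5)c(=O)c5ccccc45)cc3F)ccnc2cc1OCCCN1CCC(C)CC1` has not been measured. Among the compounds with values here, it differs from compound 3 by 4-bromophenyl in place of 2-fluorophenyl on an aromatic nitrogen, which is the same change as the one from compound 1 to compound 2, made on the core of compound 3 rather than on the core of compound 1. The two cores differ by 4-methylpiperidin-1-yl in place of pyrrolidin-1-yl on a saturated chain carbon, three bonds along the chain from an oxygen on an aromatic ring.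

Because the earlier step of a 1.2-fold higher number from compound 1 to compound 2 (0.09 log units; within the scatter) was small, the step from compound 3 to compound 4 is expected to be small as well, estimated as a 1.2-fold higher number from compound 3 to compound 4 (0.08 log units; within the scatter). The estimate for compound 4 in this assay is 800 nM, expected to lie between 400 nM and 1600 nM.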

Compound 4, half-maximal inhibitory concentration: 1160 nM
For compound 4 the middle estimate is 1.5-fold (0.16 log units) below the measured one; measured number inside the range.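

Putting 4-bromophenyl in place of 2-fluorophenyl on the core of compound 3 gives a 1.7-fold higher number from compound 3 to compound 4 (0.24 log units; within the scatter), and this agrees with the same change made on the core of compound 1: the same change on two cores in this assay, a 1.2-fold higher number (0.09 log units; within the scatter) from compound 1 to compound 2 and a 1.7-fold higher number (0.24 log units; within the scatter) from compound 3 to compound 4, 1.4-fold (0.15 log units) apart, within the scatter of two such steps. Putting 4-methylpiperidin-1-yl in place of pyrrolidin-1-yl gives no change at the digits printed from compound 2 to compound 4 (within the scatter), and this too agrees with the same change made on the other core: the same change on two cores in this assay, a 1.4-fold lower number (0.15 log units; within the scatter) from compound 1 to compound 3 and no change at the digits printed (within the scatter) from compound 2 to compound 4, 1.4-fold (0.15 log units) apart, within the scatter of two such steps. So in this assay neither change shows a detectable dependence on the core it is made on, but every step here lies within the scatter, so the four compounds show only that these two small changes stay small on these two cores, not that either change has a real effect or that any change would carry over equally well elsewhere in the series.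

The compounds shown leave open what happens with other groups, such as a 4-methoxyphenyl or a 4-cyanophenyl on the aromatic nitrogen, or a morpholin-4-yl at the end of the chain. They also leave open whether a change with a step clearly beyond the scatter would carry from one core to another as closely as these two do.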